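Dropping One Hydroxy From a Weak Thiosemicarbazone

This account rests on a few compounds, and the source may have more. Where it says the series, first, only, none or still open, it means among the compounds named here.

Three related thiosemicarbazones have been tested in a functional assay on MDA-MB-468 cells (Homo sapiens) for inhibition, read by WST assay, with a stated time of 48 h; on this read-out higher numbers stand for weaker inhibition and lower numbers for stronger inhibition. Compound 1 `Oc1ccc(/C=N\NC(=S)NC2CCCCC2)c(O)c1` gives 44600 nM, the highest number of the three, yet its gaps to compound 2 `S=C(N/N=C\c1ccc(Cl)cc1)NC1CCCCC1` at 41600 nM and to compound 3 `Oc1cccc(/C=N\NC(=S)NC2CCCCC2)c1` at 32200 nM both lie within the usual scatter, so the three cannot be told apart on these data. Compound 4 `Oc1ccc(/C=N\NC(=S)NC2CCCCC2)cc1` has not been measured; it differs from compound 1 by hydrogen in place of hydroxy on an aromatic carbon. Among the compounds with values here, no step between measured compounds is known, and all three numbers sit close together, so the estimated step of a 1.2-fold lower number from compound 1 to compound 4 (0.07 log units; within the scatter) is expected to stay within the scatter, with no clear direction. Compound 4 is therefore estimated at 38000 nM in this assay, in a range from 18000 nM to 80000 nM.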

Compound 4, half-maximal inhibitory concentration: 242000 nM
The estimate for compound 4 lay 6.4-fold (0.80 log units) below the measured number; measured number above the stated range.
By their numbers in this assay, from the lowest: compounds 3, 2 and 1 (each within the scatter of the next); then compound 4.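

In this assay the hydroxy on this aromatic carbon, ortho to a large group, does matter: hydrogen in its place gives a 5.4-fold higher number from compound 1 to compound 4 (0.73 log units; beyond the scatter) and so the first gap here that lies beyond the scatter. Hydroxy in place of chloro on an aromatic carbon gives a 5.8-fold higher number from compound 2 to compound 4 (0.76 log units; beyond the scatter) and sets compound 4 apart as the weakest of the four. On these data alone, whether an amine or a methoxy group on this carbon would keep the inhibition of compound 1 stays open. Nothing measured here explains the loss.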